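A few compounds are considered here, and "the series" means these few. Any claim that something is new, unique, unknown or untested is made for them only; others in the source may bear on it.

Working notes on the series.

Two analogues of the shared core carry different substituents on the oxygen on the aromatic ring. Compound 1 `COc1cc(OC)c2c(=O)cc(-c3ccc(OCCF)cc3)oc2c1` is the 2-fluoroethoxy member; in a functional assay (Homo sapiens) for antiproliferative activity, read by resazurin assay, with a stated time of 48 h, tested at 10 uM (a higher number here means a stronger effect of the compound at the concentration tested, a lower number a weaker effect), compound 1 comes out as "not active" (no number reported), without a number. Compound 2 `COc1cc(OC)c2c(=O)cc(-c3ccc(OC4CCN(C)CC4)cc3)oc2c1` carries the (1-methylpiperidin-4-yl)oxy group; in this assay compound 2 gives 49%. Going by the values given here, compound 2 therefore stands as the only entry in this assay with a reported number, the other entry being without one, so no step between measured compounds can be drawn.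

Compound 3 `COc1cc(OC)c2c(=O)cc(-c3ccc(OCCN4CCCC4=O)cc3)oc2c1` is the next entry. It differs from compound 2 by 2-(2-oxopyrrolidin-1-yl)ethyl in place of 1-methylpiperidin-4-yl on an oxygen on an aromatic ring. The change keeps one hydrogen-bond acceptor and no net charge, swaps a six-membered ring for a five-membered one with a double bond outside aromatic rings, and extends the linker by two carbons.

Among the compounds with values here, since no step is on record, the expectation rests on compound 2 alone. For compound 3 in this assay a downward step of a number 19 percentage points lower from compound 2 to compound 3 (beyond the scatter) beyond the scatter is expected, as the move away from the 1-methylpiperidin-4-yl group is read as a loss. Compound 3 is estimated at 30%, within 10% to 50%.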

Compound 3, a percentage reported as inhibition, at one concentration (the size of the read-out at that concentration, not a potency): 14%
Compound 3: middle estimate off by 16 percentage points, on the high side; measured number inside the range.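

In this assay, going by these compounds alone, the exchange of 1-methylpiperidin-4-yl for 2-(2-oxopyrrolidin-1-yl)ethyl on an oxygen on an aromatic ring gives a number 35 percentage points lower from compound 2 to compound 3 (beyond the scatter) and so shows that the read-out at the tested concentration depends on the group at this place, which the single number for compound 2 could not show. The two groups have the same computed counts of hydrogen-bond donors and acceptors and neither carries a net charge, so these counts do not separate compound 2 from compound 3. Nothing at hand bears on the reason for the size of this step.

The change replaces the six-membered ring with a five-membered one, adds a carbonyl and alters the link to the oxygen all at once, so this single step does not show which of these features matters; a 2-(1-methylpiperidin-4-yl)ethyl group or a 2-(pyrrolidin-1-yl)ethyl group on the same oxygen would help to separate them. Steps to compound 1 cannot be read, as it has no reported number, so the 2-fluoroethoxy group cannot yet be placed relative to the other two groups.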